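A few compounds are considered here, and "the series" means these few. Any claim that something is new, unique, unknown or untested is made for them only; others in the source may bear on it.

- compound 1: `Cc1ccc(C2=NN(c3ccc(S(C)(=O)=O)cc3)C(=O)CC2)cc1`, 5780 nM
- compound 2: `Cc1cc(O)ccc1C1=NN(c2ccc(S(C)(=O)=O)cc2)C(=O)CC1`, 92500 nM

Both values come from a functional assay on 786-0 cells (Homo sapiens) for inhibition, read by sulforhodamine B assay, with a stated time of 48 h; on this read-out lower numbers stand for stronger inhibition of growth and higher numbers for weaker inhibition of growth. Compound 2 has the higher number of the pair, which marks the weaker inhibition of growth. The measured change is a 16-fold higher number from compound 1 to compound 2 (1.20 log units; beyond the scatter), a large step beyond the scatter.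

The next compound, compound 3 `CCc1ccc(C2=NN(c3ccc(S(C)(=O)=O)cc3)C(=O)CC2)cc1`, has not yet been measured. Its difference from compound 2 is 4-ethylphenyl in place of 4-hydroxy-2-methylphenyl on a carbon with a double bond to nitrogen. Here 4-ethylphenyl takes the place of 4-hydroxy-2-methylphenyl on a carbon with a double bond to nitrogen, so the hydroxy group is gone.

Within the data shown here, only that one measured step bears on this change. In it, 4-hydroxy-2-methylphenyl replaced 4-methylphenyl, and compound 3 reverses much of that swap. However, it carries 4-ethylphenyl rather than 4-methylphenyl, and no measurement here tests that difference. A large move towards a lower number therefore seems likely, of about the same size as the measured step. The expected change is a 19-fold lower number from compound 2 to compound 3 (1.27 log units; beyond the scatter). For compound 3 the estimate is 5000 nM, with an expected range of 1500 nM to 20000 nM.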

Compound 3, concentration for 50% growth inhibition: 5130 nM
Estimate against measurement, compound 3: 1.0-fold (0.01 log units) below, and the stated range covers the measured number.
By their numbers in this assay, from the lowest: compounds 3 and 1 (each within the scatter of the next); then compound 2.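

Going from 4-methylphenyl to 4-ethylphenyl in this assay gives a 1.1-fold lower number from compound 1 to compound 3 (0.05 log units; within the scatter), so this longer chain on the phenyl ring leaves growth inhibition unchanged within the usual scatter. Removing the 4-hydroxy-2-methylphenyl group in favour of 4-ethylphenyl gives an 18-fold lower number from compound 2 to compound 3 (1.26 log units; beyond the scatter), which shows a second time, now with a different partner, that compound 2 stands apart from the two compounds that carry a simple alkyl-substituted phenyl and no hydroxy group. These data link the weaker inhibition of growth to the 4-hydroxy-2-methylphenyl group rather than to the exact alkyl chain, but no measurement available here explains why that group behaves this way.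

The three compounds cannot separate the contribution of the hydroxy group from that of the methyl group within 4-hydroxy-2-methylphenyl, and a 4-hydroxyphenyl or 2-methylphenyl group would be needed to pull the two apart. From the compounds shown here alone, how far the chain can grow also remains open, as does the outcome with a propyl, a tert-butyl, a methoxy or an amine in place of the ethyl.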